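Series notes: pyrazolylsulfonylamino for methylsulfonyl, cytotoxicity outlook

The source may report more compounds than this note shows. Statements on the series, on what has been measured and on what is new or still open speak of the compounds shown alone.

Three compounds share one core and differ only in the group on the amide-type nitrogen in the ring: compound 1 `COc1ccc([C@H]2CC(=O)N(C(=O)c3ccccc3)C2)cc1OC1CCCC1`, compound 2 `COc1ccc([C@H]2CC(=O)N(c3ccccc3N)C2)cc1OC1CCCC1` and compound 3 `COc1ccc([C@H]2CC(=O)N(c3cccc(S(C)(=O)=O)c3)C2)cc1OC1CCCC1`. In a functional assay on HEK293 cells (Homo sapiens) for cytotoxicity (on this read-out higher numbers stand for lower toxicity in this test and lower numbers for higher toxicity in this test), compound 1 gives only a limit of the assay, > 10000 nM. Compound 2 likewise gives only a limit in this assay, > 10000 nM. Compound 3 also gives only a limit in this assay, > 10000 nM. Compound 3 thus stands at the limit of > 10000 nM in this assay, at which 3 of the 3 values shown sit. The steps a step that the two limits leave unreadable from compound 1 to compound 2, a step that the two limits leave unreadable from compound 1 to compound 3 and a step that the two limits leave unreadable from compound 2 to compound 3 have no readable size. Compound 4 `COc1ccc([C@H]2CC(=O)N(c3cccc(NS(=O)(=O)c4c(Br)nn(C)c4Cl)c3)C2)cc1OC1CCCC1` differs from compound 3 by ((3-bromo-5-chloro-1-methyl-1H-pyrazol-4-yl)sulfonyl)amino in place of methylsulfonyl on an aromatic carbon. Among the measured compounds shown here, no measured step bears on this change with a readable size, so in this assay no step beyond the scatter is expected, a step that the limit leaves unreadable from compound 3 to compound 4. Compound 4 is therefore expected to give 15000 nM in this assay, within 5000 nM to 50000 nM.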

Compound 4, half-maximal cytotoxic concentration: > 10000 nM
Compound 4: a limit, no number; the forecaster's own chance of this, stated with the estimate: 75%; the middle value lies beyond the limit too.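

Compound 3 and compound 4 both give only a limit in this assay, so no step can be read between them. The compounds shown leave open what size any of these changes has, with every value at one limit: the limit of > 10000 nM in this assay, at which 4 of the 4 values shown sit.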